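Aryl Swap on the Hydroxyl-Bearing Chain Carbon

The compounds below may be only part of what the source reports. "The series", "measured", "known", "first", "only" and "open" are said of these compounds alone.

Compound 1 `OC(CCn1nc2c(Br)c(Br)c(Br)c(Br)c2n1)c1cccc(Br)c1` and compound 2 `OC(CCn1nc2c(Br)c(Br)c(Br)c(Br)c2n1)c1ccc(F)cc1` share the same core and differ only in the aromatic ring attached to the chain carbon that carries the hydroxyl group. In a functional assay on MCF7 cells (Homo sapiens) for antiproliferative activity, read by MTT assay, with a stated time of 48 h, tested at 50 uM (a lower number here means a stronger effect, a higher number a weaker effect of the compound at the concentration tested), compound 1 gives 11%, and compound 2 gives 7%. Among the compounds with values here, compound 2 stands as the lowest of the two numbers so far, with compound 1 nearest, but the step between them, a number 4 percentage points lower from compound 1 to compound 2 (within the scatter), lies within the usual scatter, so neither compound can be called stronger than the other.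

Compound 3 `COc1cccc(C(O)CCn2nc3c(Br)c(Br)c(Br)c(Br)c3n2)c1` has not yet been measured. It differs from compound 2 by 3-methoxyphenyl in place of 4-fluorophenyl on a saturated chain carbon bound to an oxygen on a saturated carbon and a saturated chain carbon. Within the data shown here, only one measured step bears on this change, the swap of the aromatic ring at the same place between compound 1 and compound 2, and that step, a number 4 percentage points lower from compound 1 to compound 2 (within the scatter), was small. Among the measured compounds shown here, no measured compound carries a 3-methoxyphenyl, so nothing shows a direct precedent. Compound 3 is therefore expected to show a number 2 percentage points higher from compound 2 to compound 3 (within the scatter), no change beyond the scatter. Compound 3 is estimated at 9%, between 2% and 22%.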

Compound 3, a percentage reported as activity, at one concentration (the size of the read-out at that concentration, not a potency): 20%
For compound 3 the middle estimate is 11 percentage points below the measured one; the range from low to high includes it.
By their numbers in this assay, from the lowest: compounds 2, 1 and 3 (each within the scatter of the next, the first and the last beyond it).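

In this assay, within the data shown here, the change from 4-fluorophenyl to 3-methoxyphenyl on the chain carbon carrying the hydroxyl group gives a number 13 percentage points higher from compound 2 to compound 3 (beyond the scatter) and is the first step at this place to pass beyond the scatter, showing that the choice of aromatic ring here can weaken the effect at the concentration tested. The ring swap is not decisive in every pair, though: methoxy in place of bromo on the aromatic carbon gives a number 9 percentage points higher from compound 1 to compound 3 (within the scatter) and so separates neither compound from the other, which means that only compound 2 and compound 3 stand clearly apart among the three. Nothing available here explains the difference between compound 2 and compound 3.

Since 4-fluorophenyl and 3-methoxyphenyl differ in both the group on the ring and where it sits, the compounds shown cannot tell which of the two matters. Going by these compounds, it also remains open how this place would respond to an unsubstituted phenyl, or to a ring bearing an amine or a carboxylic acid.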